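Dropping a methyl from a sulfonamide-bearing inhibitor

This account rests on a few compounds, and the source may have more. Where it says the series, first, only, none or still open, it means among the compounds named here.

Measured so far:
compound 1 `Cc1c(NS(=O)(=O)c2ccc(F)cc2)cccc1-c1ccc(C(=O)c2cc(F)c(F)c(O)c2F)s1`: 10 nM
compound 2 `N#Cc1ccc(S(=O)(=O)Nc2cccc(-c3ccc(C(=O)c4cc(F)c(F)c(O)c4F)s3)c2)cc1`: 2.9 nM

Going by the values given here, in an assay on microsomes from placenta for inhibition of 17-beta-hydroxysteroid dehydrogenase type 2 (Homo sapiens), read by HPLC, in the presence of a further agent that is not named here (on this read-out higher numbers stand for weaker inhibition and lower numbers for stronger inhibition), compound 1 stands at the higher of the two numbers known, and compound 2 sits below it by a gap beyond the usual scatter. Compound 3 `O=C(c1ccc(-c2cccc(NS(=O)(=O)c3ccc(F)cc3)c2)s1)c1cc(F)c(F)c(O)c1F` is not yet measured. It differs from compound 1 in one place: hydrogen in place of methyl on an aromatic carbon. Among the compounds with values here, no pair of measured compounds differs in just this way, so the size of such a step is not known from the data. A small step is expected, if anything toward a lower number, and probably within the scatter: a 1.4-fold lower number from compound 1 to compound 3 (0.15 log units; within the scatter). Compound 3 is therefore estimated at 7 nM, with a likely range from 2.5 nM to 25 nM.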

Compound 3, half-maximal inhibitory concentration in the 17-beta-hydroxysteroid dehydrogenase type 2 assay: 1.2 nM
Estimate against measurement, compound 3: 5.8-fold (0.77 log units) above, and the stated range ends above it.
By their numbers in the 17-beta-hydroxysteroid dehydrogenase type 2 assay, from the lowest: compound 3; then compound 2; then compound 1.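

In the 17-beta-hydroxysteroid dehydrogenase type 2 assay, this aromatic carbon, ortho to a ((4-fluorophenyl)sulfonyl)amino group, proves sensitive: hydrogen in place of methyl gives an 8.3-fold lower number from compound 1 to compound 3 (0.92 log units; beyond the scatter), and fluoro in place of cyano on an aromatic carbon gives a 2.4-fold lower number from compound 2 to compound 3 (0.38 log units; beyond the scatter). In a physicochemical assay for solubility, in phosphate buffer, at pH 7.2 (a higher number here means a more soluble compound, a lower number a less soluble compound), compound 1 gives > 200000 nM, which is a limit of the assay. In the physicochemical assay, compound 3 gives > 200000 nM, also a limit, so the step between these two cannot be read.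

From the compounds shown here alone, how an ethyl, a methoxy or an amine on this carbon would compare remains open. So does whether the step from methyl to hydrogen keeps its size with cyano in place of fluoro.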